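A few compounds are considered here, and "the series" means these few. Any claim that something is new, unique, unknown or untested is made for them only; others in the source may bear on it.

Values in a functional assay on HCT-116 cells (Homo sapiens) for cytotoxicity, read by sulforhodamine B assay, with a stated time of 48 h; on this read-out lower numbers stand for stronger inhibition and higher numbers for weaker inhibition:
- compound 1 `COc1ccc(C(=O)Nc2n[nH]c3c2CN(C(=O)c2ccccc2)C3)cc1`: 13600 nM
- compound 2 `CC(C)C(=O)n1nc(NC(=O)c2ccccc2)c2c1CN(C(=O)c1ccccc1)C2`: 2020 nM
- compound 3 `CC(=O)n1nc(NC(=O)c2ccccc2)c2c1CN(C(=O)C1CCC(C)CC1)C2`: 12200 nM

Compound 3, at 12200 nM, lies within the usual scatter of compound 1, so these two cannot be told apart in this assay. Compound 2 gives a clearly lower number than compound 3, which means stronger inhibition, and this gap lies beyond the scatter.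

Compound 4 `CC(=O)n1nc(NC(=O)c2ccccc2)c2c1CN(S(=O)(=O)N(C)C)C2` has not yet been measured. It carries dimethylsulfamoyl in place of (4-methylcyclohexyl)carbonyl on an amine nitrogen in a ring.

For the measured compounds named here, no pair of measured compounds differs only at this place, so the data offer no direct guide to the size or direction of the change. The best starting point is therefore compound 3 itself, at 12200 nM, and no shift beyond the scatter is expected in this assay. The expected result is a 1.0-fold lower number from compound 3 to compound 4 (0.01 log units; within the scatter). For compound 4 the estimated value is 12000 nM, with an expected range from 3500 nM to 40000 nM.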

Compound 4, half-maximal inhibitory concentration: 35300 nM
The estimate for compound 4 lay 2.9-fold (0.47 log units) below the measured number, and the stated range covers the measured number.
By their numbers in this assay, from the lowest: compound 2; then compounds 3 and 1 (each within the scatter of the next); then compound 4.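

In this assay the change to dimethylsulfamoyl in place of (4-methylcyclohexyl)carbonyl on the amine nitrogen in a ring gives a 2.9-fold higher number from compound 3 to compound 4 (0.46 log units; beyond the scatter) and so means weaker inhibition, a modest step. For the compounds shown here, this is the first direct sign that what sits on this nitrogen can shift the number, since no earlier pair differed only here. The swap alters several things at once, removing the carbon-only ring and replacing the carbonyl link with a sulfamoyl one, and no measurement shown gives a reason for the step.

As far as these compounds go, it remains open whether the ring or the link matters more. Dimethylcarbamoyl would keep the carbonyl link without the ring, and cyclohexylsulfonyl would keep a ring on a sulfur link, so the two could help separate these features.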